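Methoxy in Place of Fluoro: Estimating Compound 4

This account rests on a few compounds, and the source may have more. Where it says the series, first, only, none or still open, it means among the compounds named here.

Of the compounds shown here, three sharing one core have been measured in an ADME assay on HT-29 cells (Homo sapiens) for inhibition, read by MTT assay, with a stated time of 72 h; a higher number here means a weaker inhibitor, a lower number a stronger inhibitor. Compound 1 `C=CC(=O)Nc1cccc(Nc2nc(N/N=C/c3ccc(F)cc3)ncc2Cl)c1` gives 6340 nM. Compound 2 `CN(C)C/C=C/C(=O)Nc1cccc(Nc2nc(N/N=C/c3ccccc3F)ncc2Cl)c1` gives 3660 nM in this assay, and compound 3 `CN(C)C/C=C/C(=O)Nc1cccc(Nc2nc(N/N=C/c3ccc(F)cc3)ncc2Cl)c1` gives 3300 nM. Two single-point steps connect them: a 1.9-fold lower number from compound 1 to compound 3 (0.28 log units; within the scatter), and a 1.1-fold lower number from compound 2 to compound 3 (0.04 log units; within the scatter). Compound 3 thus sits at the low end of a narrow spread, but neither gap separates it from the other two beyond the scatter, so the three cannot be ranked against one another.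

The unmeasured compound 4 `COc1ccc(/C=N/Nc2ncc(Cl)c(Nc3cccc(NC(=O)/C=C/CN(C)C)c3)n2)cc1` differs from compound 3 in one place: methoxy in place of fluoro on an aromatic carbon. Cut one bond further out, the same change reads 4-fluorophenyl to 4-methoxyphenyl. Among the compounds with values here, only the step from compound 2 to compound 3 touches this ring, where the fluoro simply changed its place, and that step stayed within the scatter. Within the data shown here, no measured step exchanges fluoro for methoxy, so nothing among the three compounds points to a shift beyond the scatter in either direction. Compound 4 is therefore expected to give about 3300 nM in this assay, with a range from 1400 nM to 7800 nM. The estimated step of no change at the digits printed from compound 3 to compound 4 (within the scatter) is expected to stay within the scatter.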

Compound 4, half-maximal inhibitory concentration: 4820 nM
Compound 4: middle estimate off by 1.5-fold (0.16 log units), on the low side, and the stated range covers the measured number.
By their numbers in this assay, from the lowest: compounds 3, 2, 4 and 1 (each within the scatter of the next).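

In this assay, the aromatic carbon that carries fluoro in compound 3 now has a direct test of another group: exchanging fluoro for methoxy gives a 1.5-fold higher number from compound 3 to compound 4 (0.16 log units; within the scatter), so this exchange does not separate the two compounds. The comparison with the 2-fluorophenyl compound, which changes both the group and its place on the ring, gives a 1.3-fold higher number from compound 2 to compound 4 (0.12 log units; within the scatter), and it too leaves the two compounds indistinguishable. Across 2-fluorophenyl, 4-fluorophenyl and 4-methoxyphenyl, then, no step among compounds 2, 3 and 4 leaves the scatter, although no measurement at hand gives a reason for this closeness.

The compounds shown leave open whether a different group at this carbon, such as an amine, a carboxylic acid or a longer chain like ethoxy, would produce a step beyond the scatter. They also leave open whether methoxy would give a similar result with the vinyl group of compound 1 in place of the 3-(dimethylamino)prop-1-en-1-yl group of compound 3.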